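A few compounds are considered here, and "the series" means these few. Any claim that something is new, unique, unknown or untested is made for them only; others in the source may bear on it.

Compound 1 `Nc1ccccc1NC(=O)/C=C/c1ccc(Cn2cnc3c(Nc4ccccc4)nc(Cl)nc32)cc1` gives 16.4% in a functional assay on HepG2 cells (Homo sapiens) for antiproliferative activity, read by CCK-8 assay, with a stated time of 72 h, tested at 2 uM; a higher number here means a stronger effect of the compound at the concentration tested, a lower number a weaker effect.
Compound 2 `Nc1ccccc1NC(=O)/C=C/c1ccc(Cn2cnc3c(NCc4ccccc4)nc(Cl)nc32)cc1` gives 11.5% in this assay.

Compound 2 holds the lower of the two numbers, but its gap to compound 1 is within the scatter, so no order between them can be read. Compound 3 `Cc1ccc(Nc2nc(Cl)nc3c2ncn3Cc2ccc(/C=C/C(=O)Nc3ccccc3N)cc2)cc1` has not yet been measured; it differs from compound 2 by 4-methylphenyl in place of benzyl on a nitrogen on an aromatic ring. For the measured compounds named here, the only measured step, a number 4.9 percentage points lower from compound 1 to compound 2 (within the scatter), swapped a phenyl for a benzyl on the same nitrogen and stayed within the scatter. Returning to a phenyl-type group is therefore expected to shift this assay by a number 3.5 percentage points higher from compound 2 to compound 3 (within the scatter), small and within the scatter. Compound 3 is estimated at 15%, between 5% and 27%.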

Compound 3, a percentage reported as inhibition, at one concentration (the size of the read-out at that concentration, not a potency): 33.6%
Estimate against measurement, compound 3: 18.6 percentage points below; measured number outside the range, above it.
By their numbers in this assay, from the lowest: compounds 2 and 1 (each within the scatter of the next); then compound 3.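

In this assay, this nitrogen turns out to be sensitive to its substituent: 4-methylphenyl in place of benzyl gives a number 22.1 percentage points higher from compound 2 to compound 3 (beyond the scatter). A single methyl in place of hydrogen on an aromatic carbon of the phenyl ring accounts for a number 17.2 percentage points higher from compound 1 to compound 3 (beyond the scatter), so a small addition to that ring matters more than the phenyl-to-benzyl swap did. Nothing available explains why the methyl has this effect.

On these data alone, it remains open whether the methyl is specific in this role, or whether an ethyl, a methoxy, a chlorine atom or an amine on the same ring would do the same.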